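A few compounds are considered here, and "the series" means these few. Any claim that something is new, unique, unknown or untested is made for them only; others in the source may bear on it.

Compound 1 `CCOCc1c(C)coc1-c1ccc2c(c1OC)CCCC2(C)C`: 19.8 uM
Compound 2 `Cc1coc(-c2ccc3c(c2O)CCCC3)c1C(=O)O`: 32.4 uM

In a functional assay on SK-BR-3 cells (Homo sapiens) for cytotoxicity, read by sulforhodamine B assay, with a stated time of 3 days (a lower number here means that less compound is needed, a higher number that more compound is needed for the effect), compound 1 gives 19.8 uM. Compound 2 gives 32.4 uM, and these two values lie within the usual scatter of each other, so neither stands apart. Compound 3 `COC(=O)c1c(C)coc1-c1ccc2c(c1OC)CCCC2(C)C` has not yet been measured. It keeps the core of compound 1 and carries methoxycarbonyl in place of ethoxymethyl on an aromatic carbon. Going by the values given here, no measured pair shows this exchange, so no step beyond the scatter is expected in this assay. The expected size is a 1.1-fold higher number from compound 1 to compound 3 (0.05 log units; within the scatter). For compound 3 the estimated value is 22 uM, with an expected range from 9 uM to 50 uM.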

Compound 3, concentration for half-maximal effect: 27.1 uM
Estimate against measurement, compound 3: 1.2-fold (0.09 log units) below; the measured number falls inside the stated range.
By their numbers in this assay, from the lowest: compounds 1, 3 and 2 (each within the scatter of the next).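

Methoxycarbonyl in place of ethoxymethyl gives a 1.4-fold higher number from compound 1 to compound 3 (0.14 log units; within the scatter) in this assay and so offers the first direct reading at this aromatic carbon. The two groups cannot be told apart here, although methoxycarbonyl carries a double bond that ethoxymethyl lacks. Nothing available explains this result.

As far as these compounds go, whether an amine, an amide or a longer chain at this position would move the number beyond the scatter stays open. This single exchange on the core of compound 1 also cannot show how these groups would behave on another core.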